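The source may report more compounds than this note shows. Statements on the series, on what has been measured and on what is new or still open speak of the compounds shown alone.

Measured compounds in an ADME assay on Vero cells (Chlorocebus sabaeus) for cytotoxicity, with a stated time of 72 h; on this read-out lower numbers stand for stronger inhibition and higher numbers for weaker inhibition:
Compound 1 `N#Cc1ccc(-c2cccc(CO[C@@H]3COc4nc([N+](=O)[O-])cn4C3)c2)cc1` gives > 128000 nM, which is a limit of the assay.
Compound 2 `O=[N+]([O-])c1cn2c(n1)OC[C@@H](OCc1cccc(-c3ccc(F)cc3)c1)C2` gives > 128000 nM, likewise a limit.
Compound 3 `N#Cc1ccc(-n2cc(CO[C@@H]3COc4nc([N+](=O)[O-])cn4C3)nn2)cc1` gives > 128000 nM, again a limit.

Compound 1 and compound 2 differ by fluoro in place of cyano on an aromatic carbon. The step that the two limits leave unreadable from compound 1 to compound 2 cannot be sized because of the limit of > 128000 nM in this assay, at which 3 of the 3 values shown sit. The same change, at the same place, separates compound 3 from compound 4 `O=[N+]([O-])c1cn2c(n1)OC[C@@H](OCc1cn(-c3ccc(F)cc3)nn1)C2`, which has not yet been measured: fluoro in place of cyano on an aromatic carbon. The difference between the core of compound 3 and the core of compound 1 is not broken down here. The step from compound 3 to compound 4 is expected to be a step that the limit leaves unreadable from compound 3 to compound 4, resting on compound 3 sitting at a limit in this assay. Compound 4 is therefore estimated at 200000 nM, between 100000 nM and 600000 nM, most likely again reported only as a limit.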

Compound 4, half-maximal inhibitory concentration: > 128000 nM
Compound 4 was reported as a limit (the forecaster's own chance of this, stated with the estimate: 90%); the middle value is on the limit's open side.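

In this assay, compound 3 and compound 4 both sit at a limit, so no step can be read between them: the limit of > 128000 nM in this assay, at which 4 of the 4 values shown sit.

The compounds shown leave open whether fluoro in place of cyano changes this read-out at all.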